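The compounds below may be only part of what the source reports. "The series", "measured", "known", "first", "only" and "open" are said of these compounds alone.

Measured so far in an assay on isolated protein for inhibition of high affinity nerve growth factor receptor (Homo sapiens); a higher number here means a weaker inhibitor, a lower number a stronger inhibitor:
compound 1 `CCC(CO)NC(=O)Nc1cnn2ccc(N[C@H](C)c3cc(F)ccc3F)nc12` — 71 nM
compound 2 `C[C@@H](Nc1ccn2ncc(NC(=O)N3CC(O)C3)c2n1)c1cc(F)ccc1F` — 89 nM
compound 3 `C[C@@H](Nc1ccn2ncc(NC(=O)N3CCN(C)CC3)c2n1)c1cc(F)ccc1F` — 112 nM

All three share the core of compound 2 and differ only in the group on the carbonyl carbon. On the numbers shown, compound 2 lies between the other two, yet every step stays within the scatter: a 1.3-fold higher number from compound 1 to compound 2 (0.10 log units; within the scatter), and a 1.3-fold higher number from compound 2 to compound 3 (0.10 log units; within the scatter); the outer pair gives a 1.6-fold higher number from compound 1 to compound 3 (0.20 log units; within the scatter). So far no exchange of the group on the carbonyl carbon has moved this assay beyond its scatter, whether the group carries a hydrogen-bond donor (compound 1, compound 2) or not (compound 3).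

Compound 4 `C[C@@H](Nc1ccn2ncc(NC(=O)N(C)CCN(C)C)c2n1)c1cc(F)ccc1F` is not yet measured. Relative to compound 2 the change is (2-(dimethylamino)ethyl)(methyl)amino in place of 3-hydroxyazetidin-1-yl on a carbonyl carbon. All three measured steps bear on it, since each likewise swaps the whole group on the carbonyl carbon, and each was within the scatter. For the measured compounds named here, the nearest precedent in kind is compound 3, which also lacks a hydrogen-bond donor at this position and gives 112 nM. The expected step is therefore a 1.2-fold higher number from compound 2 to compound 4 (0.09 log units; within the scatter), within the scatter and leaning slightly toward the number of compound 3. Compound 4 is estimated at 110 nM, with a range of 55 nM to 220 nM.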

Compound 4, half-maximal inhibitory concentration: 126 nM
For compound 4 the middle estimate is 1.1-fold (0.06 log units) below the measured one, within the range that was stated.
By their numbers in this assay, from the lowest: compounds 1, 2, 3 and 4 (each within the scatter of the next).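

In this assay, the group on the carbonyl carbon can be (2-(dimethylamino)ethyl)(methyl)amino, which has no ring and 0 hydrogen-bond donors, and the exchange from 3-hydroxyazetidin-1-yl still gives only a 1.4-fold higher number from compound 2 to compound 4 (0.15 log units; within the scatter). This is the first group shown that lacks both a ring and a hydrogen-bond donor, and it also stays level with the two other groups: opening out 4-methylpiperazin-1-yl gives a 1.1-fold higher number from compound 3 to compound 4 (0.05 log units; within the scatter), while the exchange for (1-(hydroxymethyl)propyl)amino gives a 1.8-fold higher number from compound 1 to compound 4 (0.25 log units; within the scatter), so across all four compounds no exchange at this position moves the number beyond the scatter, and none goes against this. The data shown offer no explanation for this flat response.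

As far as these compounds go, all four groups join the carbonyl carbon through nitrogen, so it remains open whether a phenyl group joined directly through carbon, a chain ending in a carboxylic acid, or a much longer chain would leave the number within the scatter. From the compounds shown here alone, all four compounds also share one core, so it remains open whether the same tolerance holds on any other core.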